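Formyl for methyl on the fused core of the series

This account rests on a few compounds, and the source may have more. Where it says the series, first, only, none or still open, it means among the compounds named here.

Measured compounds:
- compound 1, `COc1ccc(C(=O)Oc2c(-c3ccccc3)c(-c3ccccc3)n3ccc(C#N)cc23)cc1`: "not determined" (no result reported)
- compound 2, `N#Cc1ccn2c(-c3ccccc3)c(-c3ccccc3)c(CO)c2c1`: 34000 nM
- compound 3, `Cc1c(-c2ccccc2)c(-c2ccccc2)n2ccc(C#N)cc12`: "not determined" (no result reported)

The three compounds share one core and differ only in the group on the aromatic carbon of the five-membered ring. Among the measured compounds shown here, compound 2 is the only one with a number: in an assay for inhibition of Polyunsaturated fatty acid lipoxygenase ALOX15 (Oryctolagus cuniculus) (on this read-out lower numbers stand for stronger inhibition and higher numbers for weaker inhibition), compound 2 gives 34000 nM. For the measured compounds named here, for compound 1 and compound 3 nothing was reported, so compound 3 stands without a place on the numbers, and no step between measured compounds can be stated.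

Compound 4, `N#Cc1ccn2c(-c3ccccc3)c(-c3ccccc3)c(C=O)c2c1`, is the next one to be measured. It differs from compound 3 by formyl in place of methyl on an aromatic carbon. Going by the values given here, with no value for compound 3 the size of this step in this assay cannot be given; the only anchor is compound 2 with its 34000 nM, and the formyl group is expected to fall in the same weak range rather than to move the series by more than the scatter.

Compound 4 is therefore estimated at 30000 nM, with a range from 8000 nM to 100000 nM.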

Compound 4, half-maximal inhibitory concentration: 61000 nM
The estimate for compound 4 lay 2.0-fold (0.31 log units) below the measured number; the measured number falls inside the stated range.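

Compound 4 gives the series a second number at this aromatic carbon: in this assay, formyl in place of hydroxymethyl gives a 1.8-fold higher number from compound 2 to compound 4 (0.25 log units; within the scatter), so the two groups cannot be told apart here, and both compounds sit at high numbers on this read-out. Compound 1 and compound 3 have no reported result, so the steps from their groups, including that from methyl to formyl, cannot be read. Nothing at hand gives a reason for the result.

On these data alone, whether a carboxylic acid, an amine or a longer chain at this carbon would give a number beyond the scatter of these two remains open. The shared core is also unchanged throughout, so the compounds shown say nothing about the nitrile or the phenyl groups.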